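Swapping ethyl for 4-fluorophenyl: what happens to cytotoxicity?

A few compounds are considered here, and "the series" means these few. Any claim that something is new, unique, unknown or untested is made for them only; others in the source may bear on it.

In an ADME assay on MDBK cells (Bos taurus) for cytotoxicity, read by MTT assay, with a stated time of 96 h (on this read-out higher numbers stand for lower toxicity in this test and lower numbers for higher toxicity in this test), compound 1 `N#Cc1ccc(NC(=S)Nc2cccc(C(F)(F)F)c2)cc1` gives 10000 nM. Compound 2 `CCNC(=S)Nc1cccc(C(F)(F)F)c1` reads > 100000 nM, which is a limit of the assay and not a number. Compound 3 `Fc1ccc(NC(=S)Nc2cccc(C(F)(F)F)c2)cc1` has 4-fluorophenyl in place of ethyl on an amide-type nitrogen. The expectation for it rests on compound 1, which also carries a six-membered aromatic ring on that nitrogen and gives 10000 nM. A step beyond the scatter toward higher toxicity in this assay is therefore expected, estimated as an at least 8.3-fold lower number from compound 2 to compound 3 (0.92 log units; beyond the scatter). Compound 3 is expected at 12000 nM, with an estimated range of 4000 nM to 40000 nM.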

Compound 3, half-maximal cytotoxic concentration: 41000 nM
The estimate for compound 3 lay 3.4-fold (0.53 log units) below the measured number; measured number outside the range, above it.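

Putting 4-fluorophenyl in place of ethyl on the amide-type nitrogen gives an at least 2.4-fold lower number from compound 2 to compound 3 (0.38 log units; beyond the scatter) in this assay, so the aromatic ring at this position comes with higher toxicity in this test. On these data alone, the true size of that step stays unknown because compound 2 reads a limit of the assay and not a number: the limit of > 100000 nM in this assay, at which 1 of the 3 values shown sits. The group on the ring counts as well: fluoro in place of cyano on an aromatic carbon gives a 4.1-fold higher number from compound 1 to compound 3 (0.61 log units; beyond the scatter), so the ring alone does not set the number.

Still open, as far as these compounds go, is how an amine or a carboxylic acid on that ring would read in this assay. Also open, from the compounds shown here alone, is whether a longer chain in place of ethyl would stay at the limit.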